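The compounds below may be only part of what the source reports. "The series", "measured", "known", "first", "only" and "open" are said of these compounds alone.

Measured in a functional assay on U-87MG ATCC cells for antiproliferative activity against U-87 MG (Homo sapiens), read by MTT assay, with a stated time of 48 h; a higher number here means a weaker inhibitor, a lower number a stronger inhibitor:
compound 1 `COc1ccc(-c2nc(SCC(=O)c3sc(-c4ccccc4)nc3C)[nH]c(=O)c2C#N)cc1` gives 48400 nM
compound 2 `Cc1nc(-c2ccccc2)sc1C(=O)CSc1nc(-c2cccc(Cl)c2)c(C#N)c(=O)[nH]1` gives 28200 nM
compound 3 `COc1ccc(-c2nc(SCC(=O)c3sc(-c4ccc(Cl)cc4)nc3C)[nH]c(=O)c2C#N)cc1` gives 35500 nM

All three values lie within the scatter of one another, and the step of a 1.7-fold lower number from compound 1 to compound 2 (0.23 log units; within the scatter) is likewise within it. The difference between the core of compound 2 and the core of compound 3 is not broken down here.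

Compound 4 `Cc1nc(-c2ccccc2)sc1C(=O)CSc1nc(-c2ccccc2)c(C#N)c(=O)[nH]1` is not yet measured. It is related to compound 2 by hydrogen in place of chloro on an aromatic carbon. The same kind of change separates compound 3 from compound 1, (hydrogen in place of chloro on an aromatic carbon), where the place is para to a large group rather than meta to a large group; that step gave a 1.4-fold higher number from compound 3 to compound 1 (0.13 log units; within the scatter). Among the measured compounds shown here, a step of similar size is expected for compound 4, a 1.2-fold higher number from compound 2 to compound 4 (0.08 log units; within the scatter), resting on the single measured example of this kind of change, a 1.4-fold higher number from compound 3 to compound 1 (0.13 log units; within the scatter). Compound 4 is therefore estimated at 34000 nM, with a likely range from 17000 nM to 68000 nM.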

Compound 4, half-maximal inhibitory concentration: 56600 nM
Compound 4: middle estimate off by 1.7-fold (0.22 log units), on the low side; low and high end bracket the measured number.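

In this assay, hydrogen in place of chloro reads alike on the two cores, with the gap between the two steps inside the scatter: the same change on two cores in this assay, a 1.4-fold higher number (0.13 log units; within the scatter) from compound 3 to compound 1 and a 2.0-fold higher number (0.30 log units; within the scatter) from compound 2 to compound 4, 1.5-fold (0.17 log units) apart, within the scatter of two such steps. Taken alone, the step of a 2.0-fold higher number from compound 2 to compound 4 (0.30 log units; within the scatter) also stays within the scatter, as does the step with hydrogen in place of methoxy, a 1.2-fold higher number from compound 1 to compound 4 (0.07 log units; within the scatter). The change therefore carries across these two cores without a detectable difference, but two pairs of this kind do not show that chloro has a real effect on either core, nor that the agreement extends to other cores.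

From the compounds shown here alone, it remains open whether an amine or a carboxylic acid on that aromatic carbon would give a step beyond the scatter.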